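Swapping methoxy for phenyl on compound 3

This account rests on a few compounds, and the source may have more. Where it says the series, first, only, none or still open, it means among the compounds named here.

In an ADME assay on Jurkat cells (Homo sapiens) for cytotoxicity, read by MTT assay (a higher number here means a weaker inhibitor, a lower number a stronger inhibitor), compound 1 (`O/N=C(\COc1cccc2ccccc12)c1ccccc1`) reads > 50000 nM, which is a limit of the assay and not a number. Compound 2 (`O/N=C(\COc1cccc2ccccc12)c1ccc(F)cc1`) reads > 50000 nM, again a limit. Within the data shown here, compound 3 (`COc1ccc(/C(COc2cccc3ccccc23)=N/O)cc1`) gives 31800 nM, the only actual number among the three.

Compound 4 (`O/N=C(\COc1cccc2ccccc12)c1ccc(-c2ccccc2)cc1`) has phenyl in place of methoxy on an aromatic carbon.

Three measured steps change this same place. Fluoro in place of hydrogen gave a step that the two limits leave unreadable from compound 1 to compound 2. Methoxy in place of hydrogen gave an at least 1.5-fold lower number from compound 1 to compound 3 (0.19 log units; that floor lies within the scatter), and methoxy in place of fluoro gave an at least 1.5-fold lower number from compound 2 to compound 3 (0.19 log units; that floor lies within the scatter). These steps show no change that clearly exceeds the scatter, though the true sizes of the last two could be larger than their floors. None of them brings in a new ring, so the data offer no direct guide to phenyl.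

With so little to go on, no clear shift in either direction is expected, and the value of compound 3, 31800 nM, is the best anchor. The expected step is a 1.1-fold lower number from compound 3 to compound 4 (0.06 log units; within the scatter), with no move beyond the scatter anticipated. For compound 4 the estimated value is 28000 nM, with an expected range from 10000 nM to 50000 nM.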

Compound 4, half-maximal inhibitory concentration: > 50000 nM
Compound 4 was reported as a limit; the forecaster's own chance of this, stated with the estimate: 35%; middle value at least 1.7-fold (0.25 log units) away from the limit.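

In this assay, among these compounds, placing a whole second aromatic ring on this carbon, with phenyl replacing methoxy, gives an at least 1.5-fold higher number from compound 3 to compound 4 (0.19 log units; that floor lies within the scatter), so this is the first test of a ring at this place, and it produces no stronger reading than the small methoxy group did. The result for compound 4 is a limit and not a number, the same limit carried by compound 1 and compound 2: the limit of > 50000 nM in this assay, at which 3 of the 4 values shown sit. Of the para-substituted compounds shown, only the methoxy compound therefore gives a real number, although the floor of its step to compound 4 lies within the scatter, and the steps joining compound 4 to compound 1 and compound 2 cannot be read.

From the compounds shown here alone, how far compound 1, compound 2 and compound 4 each lie past the limit remains open, so no order can be given among them. Also open, going by these compounds, is whether an amine, a carboxylic acid or a longer ether chain at this same place would stay at the limit or give a readable number. Compound 3 gives a readable number: 31800 nM.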